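A Chlorophenyl Ring Added to a Weak Inhibitor

The source may report more compounds than this note shows. Statements on the series, on what has been measured and on what is new or still open speak of the compounds shown alone.

In a functional assay on MCF7 cells (Homo sapiens) for inhibition, read by resazurin assay, with a stated time of 72 h (a lower number here means a stronger inhibitor, a higher number a weaker inhibitor), compound 3 `c1ccc(-c2ccn3ncnc3n2)cc1` gives 3910 nM. Among the measured compounds shown here, that is the only actual number among the three results; the other two are limits of the assay. Compound 1 `Fc1ccc(-c2ccn3ncnc3n2)cn1` gives only the limit > 100000 nM. Compound 2 `Clc1ccccc1-c1ccn2ncnc2n1` likewise gives only the limit > 100000 nM. For the measured compounds named here, the single measured step that joins two compounds, an at least 25-fold lower number from compound 2 to compound 3 (1.40 log units; beyond the scatter), shows that removing the chloro of compound 2 turned a limit into a number; how large that step is can be stated only through (the limit of > 100000 nM in this assay, at which 2 of the 3 values shown sit). Compound 4 `Clc1ccccc1-c1ccccc1-c1ccn2ncnc2n1` carries 2-chlorophenyl in place of hydrogen on an aromatic carbon. Going by the values given here, no measured step adds a whole ring, so the earlier step guides only loosely: compound 2 with its chloro sat at the limit, and compound 4 brings a chlorine back, though on a further ring. A moderate weakening beyond the scatter is therefore expected. Compound 4 is expected to give 9000 nM, within a range from 2000 nM to 60000 nM. The expected step is a 2.3-fold higher number from compound 3 to compound 4 (0.36 log units; beyond the scatter).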

Compound 4, half-maximal inhibitory concentration: > 100000 nM
Compound 4 gave a limit, no number; the forecaster's own chance of this, stated with the estimate: 25%; middle value at least 11-fold (1.04 log units) from the limit.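

Placing 2-chlorophenyl on an aromatic carbon of the six-membered carbon ring, ortho to a group of 9 heavy atoms, gives an at least 25-fold higher number from compound 3 to compound 4 (1.40 log units; beyond the scatter) in this assay. So a chlorine need not sit directly on this carbon for the measurable number to be lost: with a whole ring in between, the result is again a limit. Compound 2 and compound 4 are both limits, so the step between them cannot be read, and the set now clusters at one ceiling: the limit of > 100000 nM in this assay, at which 3 of the 4 values shown sit.

The compounds shown leave open whether the added ring or its chlorine matters more, since a plain phenyl ring at this carbon is not among them. They also leave open whether a small group here, such as a methyl or an amine, would keep a measurable number.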